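Swapping the Aryl Ring on a Cyclopentenyl Sulfonamide

The compounds below may be only part of what the source reports. "The series", "measured", "known", "first", "only" and "open" are said of these compounds alone.

Compound 1 `O=C(O)COCCCCC1=CCC[C@@H]1NS(=O)(=O)c1ccc(Cl)c(Cl)c1` was tested in a functional assay on a cell-free system (plasma) for inhibition of thromboxane A2 receptor (Homo sapiens), read by turbidimetry (on this read-out lower numbers stand for stronger inhibition and higher numbers for weaker inhibition), where compound 1 gives 1900 nM. Compound 3 `O=C(O)CC/C=C\CC1=CCC[C@@H]1NS(=O)(=O)c1ccc(Cl)c(Cl)c1` gives 1900 nM in this assay, and compound 2 `O=C(O)CCC/C=C\CC1=CCC[C@@H]1NS(=O)(=O)c1ccccc1[N+](=O)[O-]` gives 680 nM. On these numbers compound 1 stands level with compound 3, the two together holding the highest values of the three, while compound 2 lies furthest away with a lower number that goes beyond the scatter. For the measured compounds named here, the only step that changes a single place, no change at the digits printed from compound 1 to compound 3 (within the scatter), concerns the chain and not the ring on the sulfonyl sulfur.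

Compound 4 `O=C(O)COCCCCC1=CCC[C@@H]1NS(=O)(=O)c1ccc(F)cc1F` has not been measured. It differs from compound 1 by 2,4-difluorophenyl in place of 3,4-dichlorophenyl on a sulfonyl sulfur. Going by the values given here, no measured pair changes this ring alone: compound 2 carries a different ring, but also a different chain, so its value cannot be assigned to either change. Among the compounds with values here, because the chain step no change at the digits printed from compound 1 to compound 3 (within the scatter) was flat, and no measured step speaks to the ring, the account expects a step of a 1.3-fold higher number from compound 1 to compound 4 (0.12 log units; within the scatter) that stays within the scatter, leaning if anything toward weaker inhibition. Compound 4 is therefore estimated at 2500 nM, with a range from 900 nM to 7000 nM.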

Compound 4, half-maximal inhibitory concentration: 1800 nM
Estimate against measurement, compound 4: 1.4-fold (0.14 log units) above; the range from low to high includes it.
By their numbers in this assay, from the lowest: compound 2; then compounds 4, 1 and 3 (each within the scatter of the next).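

In this assay, for the compounds shown here, the ring on the sulfonyl sulfur is now changed with the chain held fixed, and 2,4-difluorophenyl in place of 3,4-dichlorophenyl gives a 1.1-fold lower number from compound 1 to compound 4 (0.02 log units; within the scatter) so the two rings cannot be told apart on this read-out when the chain is the one carried by compound 1. Alongside the chain step no change at the digits printed from compound 1 to compound 3 (within the scatter) this means that neither single change measured from compound 1 moves the number beyond the scatter, which holds for these two steps only. No measured property of either ring accompanies this result, and the data offer no explanation for it.

As far as these compounds go, compound 2 gives 680 nM and differs from compound 1 in both ring and chain, so what remains open is which of the two changes carries its lower number. Also open is whether an unsubstituted phenyl or a methoxyphenyl on the sulfonyl sulfur, or a tetrazole in place of the carboxylic acid, would move the number beyond the scatter on the chains shown here.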